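Swapping the aryl ring on a thioether-linked nucleoside

A few compounds are considered here, and "the series" means these few. Any claim that something is new, unique, unknown or untested is made for them only; others in the source may bear on it.

Three nucleoside analogues sharing one core have been measured in an assay on isolated protein for binding affinity to Equilibrative nucleoside transporter 1 (Homo sapiens); on this read-out lower numbers stand for stronger inhibition and higher numbers for weaker inhibition. Compound 1 `OC[C@H]1O[C@@H](n2cnc3c(Sc4ccccc4)ncnc32)[C@H](O)[C@@H]1O` gives 91200 nM. Compound 2 `Cc1ccc(CSc2ncnc3c2ncn3[C@@H]2O[C@H](CO)[C@@H](O)[C@H]2O)cc1` gives 457 nM, and compound 3 `OC[C@H]1O[C@@H](n2cnc3c(CSc4ccccc4F)ncnc32)[C@H](O)[C@@H]1O` gives 355 nM. The step of a 200-fold lower number from compound 1 to compound 2 (2.30 log units; beyond the scatter) and the step of a 260-fold lower number from compound 1 to compound 3 (2.41 log units; beyond the scatter) are both large, whereas the step of a 1.3-fold lower number from compound 2 to compound 3 (0.11 log units; within the scatter) is within the scatter, so compound 3 stands with the lowest number of the three but is not separable from compound 2.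

Compound 4 `N#Cc1ccc(SCc2ncnc3c2ncn3[C@@H]2O[C@H](CO)[C@@H](O)[C@H]2O)cc1` differs from compound 3 by the change (4-cyanophenyl in place of 2-fluorophenyl on a sulfur). Going by the values given here, the only step that bears on exchanging one aryl group for another while the sulfur linkage is kept is the step from compound 2 to compound 3, which was within the scatter. On that basis the step of a 1.1-fold higher number from compound 3 to compound 4 (0.05 log units; within the scatter) is expected to be small, with no direction beyond the scatter. For compound 4 in this assay the estimate is 400 nM, with a range from 120 nM to 1500 nM.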

Compound 4, half-maximal inhibitory concentration: 81.3 nM
The estimate for compound 4 lay 4.9-fold (0.69 log units) above the measured number, and the stated range ends above it.
By their numbers in this assay, from the lowest: compound 4; then compounds 3 and 2 (each within the scatter of the next); then compound 1.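

In this assay, 4-cyanophenyl in place of 2-fluorophenyl on a sulfur whose other neighbour is a saturated chain carbon gives a 4.4-fold lower number from compound 3 to compound 4 (0.64 log units; beyond the scatter) and so moves the number beyond the scatter. Going by these compounds alone, the earlier compounds did not show this: the one earlier step that changed the aryl group, from compound 2 to compound 3, also changed its link to the core and stayed within the scatter. With the linkage held fixed, the read-out proves sensitive to the aryl group at this place, although nothing available accounts for the step.

The change removes the fluorine and adds the nitrile at once, so the compounds shown do not say which of the two carries the step. They also leave open how a plain phenyl, or an amine or a carboxylic acid in place of the nitrile, would read at this place.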